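Cytotoxicity notes on a chloro-to-fluoro exchange

This account rests on a few compounds, and the source may have more. Where it says the series, first, only, none or still open, it means among the compounds named here.

Measured so far in an ADME assay on MT4 cells (Homo sapiens) for cytotoxicity, read by XTT assay, with a stated time of 3 days; on this read-out lower numbers stand for higher toxicity in this test and higher numbers for lower toxicity in this test:
- compound 3, `CC(C)c1c(OC2CCCCC2C)cc(Cc2ccc(Cl)cc2)[nH]c1=O`: 84000 nM
- compound 1, `CC(C)c1c(Cc2ccccc2)n(COCc2ccccc2)c(=O)[nH]c1=O`: 84600 nM
- compound 2, `CC1CCCCC1Oc1cc(CCc2ccccc2)[nH]c(=O)c1I`: only a limit, given below

In this assay compound 3 gives 84000 nM and compound 1 gives 84600 nM; the two numbers sit within the scatter of each other, so neither can be placed above the other. Compound 2 gives only > 300000 nM, which is a limit of this test and not a number (the limit of > 300000 nM in this assay, at which 1 of the 3 values shown sits). Compound 3 is thus one of two compounds with a real number, and it cannot be told apart from compound 1.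

Compound 4, `CC(C)c1c(OC2CCCCC2C)cc(Cc2ccc(F)cc2)[nH]c1=O`, differs from compound 3 in one place: fluoro in place of chloro on an aromatic carbon. Among the compounds with values here, no measured pair shows that change, so there is no step to lean on. Given that only one halogen is swapped for another at the same place, the step from compound 3 to compound 4 in this assay is expected to stay within the scatter, with at most a slight move toward a higher number: a 1.2-fold higher number from compound 3 to compound 4 (0.08 log units; within the scatter). Compound 4 is therefore estimated at 100000 nM, with a range from 40000 nM to 300000 nM.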

Compound 4, half-maximal cytotoxic concentration: 64600 nM
Compound 4: middle estimate off by 1.5-fold (0.19 log units), on the high side; the measured number falls inside the stated range.
By their numbers in this assay, from the lowest: compounds 4, 3 and 1 (each within the scatter of the next). At a limit, above all of these: compound 2.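

In this assay, within the data shown here, the exchange of chloro for fluoro, 4-chlorobenzyl to 4-fluorobenzyl on the shared core, gives a 1.3-fold lower number from compound 3 to compound 4 (0.11 log units; within the scatter) as the first one-place step. At this place on the aromatic ring, the read-out therefore does not separate the two halogens, and the step gives no sign that the cytotoxicity number depends on which of them is present. Nothing in hand gives a measured property that bears on this step.

Going by these compounds, how this place responds to groups other than halogens stays open: an amine, a carboxylic acid or a longer chain in place of the halogen could read differently. Compound 1 and compound 2 differ from compound 3 in more than one place, so this single pair carries no pattern beyond compound 3 and compound 4.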